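A few compounds are considered here, and "the series" means these few. Any claim that something is new, unique, unknown or untested is made for them only; others in the source may bear on it.

Measured in a functional assay, with a stated time of 30 min; a higher number here means a weaker inhibitor, a lower number a stronger inhibitor:
- compound 1 `COC(=O)c1c(C(=O)c2c(O)cc(C)cc2OC)c(OC)cc(O)c1[S@+](C)[O-]`: > 100000 nM
- compound 2 `COC(=O)c1c2c(cc(OC)c1C(=O)c1c(O)cc(C)cc1OC)O[C@H](OC)CS2`: > 100000 nM

Compound 1 gives > 100000 nM, and this is a limit of the assay, not a number. Compound 2 gives > 100000 nM, which is also a limit. Within the data shown here, the series therefore offers only (the limit of > 100000 nM in this assay, at which 2 of the 2 values shown sit), and no measured step is available to scale a change.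

Compound 3 `COC(=O)CSc1c(O)cc(OC)c(C(=O)c2c(O)cc(C)cc2OC)c1C(=O)OC` keeps the core of compound 1 and differs in one place: a group of 6 heavy atoms (3 carbon, 2 oxygen, 1 sulfur; no ring) in place of a group of 3 heavy atoms (1 carbon, 1 oxygen, 1 sulfur; no ring), on an aromatic carbon. The group that enters is ((methoxycarbonyl)methyl)sulfanyl, on an aromatic carbon, ortho to a hydroxy group and ortho to a methoxycarbonyl group.

No step beyond the scatter is expected in this assay, and the estimated change is a number no higher from compound 1 to compound 3 (the limit leaves the size open). This expectation rests on (the limit of > 100000 nM in this assay, at which 2 of the 2 values shown sit). The estimate for compound 3 is 100000 nM, with an expected range of 30000 nM to 300000 nM.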

Compound 3, half-maximal inhibitory concentration: > 100000 nM
Compound 3 gave a limit, no number (the forecaster's own chance of this, stated with the estimate: 75%); the middle value lies on the limit itself.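

In this assay compound 3 gives > 100000 nM, which is a limit and not a number. Compound 1 also stands at a limit, so no step can be read from compound 1 to compound 3. The compounds shown leave open which change to the shared core, if any, would give a measured number: the limit of > 100000 nM in this assay, at which 3 of the 3 values shown sit.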